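This account rests on a few compounds, and the source may have more. Where it says the series, first, only, none or still open, it means among the compounds named here.

Of the compounds shown here, two that share one core have been tested in a functional assay on the whole organism for inhibition, with Rattus norvegicus as the target, read by paw edema, with a stated time of 4 h, at a dose of 70 mg/kg by the oral route; a higher number here means more inhibition at the dose given (going by the name of the read-out), a lower number less inhibition. Compound 1 `Clc1ccccc1-c1nnc(-c2ccncc2)o1` carries a chloro group on its outer benzene ring and in this assay compound 1 gives 37.7%. Compound 2 `Cc1ccccc1-c1nnc(-c2ccncc2)o1` carries a methyl group in the same place instead, and in this assay compound 2 gives 43.4%. Among the measured compounds shown here, the one step measured, a number 5.7 percentage points higher from compound 1 to compound 2 (within the scatter), lies within the scatter, so compound 2 and compound 1 cannot be told apart on these numbers.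

Compound 3 `CC(=O)Oc1ccccc1-c1nnc(-c2ccncc2)o1` differs from compound 2 by acetoxy in place of methyl on an aromatic carbon. For the measured compounds named here, no measured step swaps a methyl for an acetoxy, and the one step that does exist, a number 5.7 percentage points higher from compound 1 to compound 2 (within the scatter), was small. With no evidence of a large effect from changing this group, compound 3 is expected to show a step of a number 1.4 percentage points lower from compound 2 to compound 3 (within the scatter), nothing beyond the scatter. Compound 3 is therefore estimated at 42%, within a range from 28% to 56%.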

Compound 3, a percentage reported as inhibition, in the whole organism at one dose (the size of the read-out at that dose, not a potency): 63.4%
The estimate for compound 3 lay 21.4 percentage points below the measured number; the whole stated range lies below it.
By their numbers in this assay, from the lowest: compounds 1 and 2 (each within the scatter of the next); then compound 3.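

Acetoxy in place of methyl at this aromatic carbon, ortho to a large group, gives a number 20 percentage points higher from compound 2 to compound 3 (beyond the scatter) in this assay and acetoxy in place of chloro gives a number 25.7 percentage points higher from compound 1 to compound 3 (beyond the scatter) in the same assay. Chloro and methyl could not be told apart, so only now is it clear that the group at this place can shift the inhibition seen at this dose, with acetoxy bringing 4 heavy atoms and 2 hydrogen-bond acceptors where methyl has 1 heavy atom and 0 acceptors. Nothing available explains why the number rose.

The compounds shown leave open whether the whole acetoxy group is needed or whether a smaller group such as hydroxy or methoxy would give a similar number. They also leave open how an amine, a carboxylic acid or a longer ester chain would fare at this place.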